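The source may report more compounds than this note shows. Statements on the series, on what has been measured and on what is new or still open speak of the compounds shown alone.

Among the measured compounds shown here, in a functional assay on A549 cells (Homo sapiens) for cytotoxicity, read by sulforhodamine B assay (on this read-out higher numbers stand for weaker inhibition and lower numbers for stronger inhibition), compound 2 `C=C1[C@@H](OC(C)=O)C[C@@H]2[C@](C)(COC=O)[C@H](OC(C)=O)CC[C@@]2(C)[C@@H]1C[C@@H](Nc1ccc(Br)cc1)C1=CCOC1=O` gives 15900 nM, the highest of the three numbers measured so far. For the measured compounds named here, compound 1 `C=C1[C@@H](OC(C)=O)C[C@@H]2[C@](C)(CO[Si](C)(C)C(C)(C)C)[C@H](OC(C)=O)CC[C@@]2(C)[C@@H]1C[C@@H](Nc1ccccc1)C1=CCOC1=O` gives 4500 nM and compound 3 `C=C1[C@@H](OC(C)=O)C[C@@H]2[C@](C)(CO[Si](C)(C)C(C)(C)C)[C@H](OC(C)=O)CC[C@@]2(C)[C@@H]1C[C@@H](Nc1cccc2ccccc12)C1=CCOC1=O` gives 4970 nM; the only step between two compounds differing in one place, a 1.1-fold higher number from compound 1 to compound 3 (0.04 log units; within the scatter), put naphthalen-1-yl in place of phenyl on an amine nitrogen. Compound 4 `C=C1[C@@H](OC(C)=O)C[C@@H]2[C@](C)(COC=O)[C@H](OC(C)=O)CC[C@@]2(C)[C@@H]1C[C@@H](Nc1ccc(OC)cc1)C1=CCOC1=O` differs from compound 2 by methoxy in place of bromo on an aromatic carbon. Going by the values given here, no measured step exchanges one substituent for another on that ring, and the step from compound 1 to compound 3 is the only guide to altering the aryl group. The expected step is a 1.4-fold lower number from compound 2 to compound 4 (0.16 log units; within the scatter), not beyond the scatter. Compound 4 is therefore estimated at 11000 nM, between 4500 nM and 27000 nM.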

Compound 4, half-maximal inhibitory concentration: 28900 nM
The estimate for compound 4 lay 2.6-fold (0.42 log units) below the measured number; the measured number lies above the stated range.
By their numbers in this assay, from the lowest: compounds 1 and 3 (each within the scatter of the next); then compounds 2 and 4 (each within the scatter of the next).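

In this assay, among the compounds shown here, the exchange of bromo for methoxy on the aromatic ring, para to a large group, gives a 1.8-fold higher number from compound 2 to compound 4 (0.26 log units; within the scatter) and is the first direct exchange of one substituent for another at this position. Within this pair, 4-bromophenyl and 4-methoxyphenyl cannot be told apart, even though methoxy brings an oxygen as a hydrogen-bond acceptor. Nothing shown offers any explanation for this result. The compounds shown leave open whether an amine or a carboxylic acid at this position would give a number beyond the scatter from compound 2.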